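Adding a Chloro to the Benzamide Aryl of Compound 2

The compounds below may be only part of what the source reports. "The series", "measured", "known", "first", "only" and "open" are said of these compounds alone.

In a functional assay on OVCAR-3 cells (Homo sapiens) for inhibition, read by sulforhodamine B assay, with a stated time of 48 h (on this read-out higher numbers stand for weaker inhibition and lower numbers for stronger inhibition), compound 2 `COc1cc(-c2nn(-c3cccc(NC(=O)c4cccc(C(F)(F)F)c4)c3)cc2-c2ccncc2)ccc1Cl` gives 1200 nM. Of the two compounds measured, that is the higher number, yet its nearest neighbour, compound 1 `O=C(Nc1cccc(-n2cc(-c3ccncc3)c(-c3ccc(Cl)c(O)c3)n2)c1)Nc1cccc(C(F)(F)F)c1` with 1060 nM, lies within the scatter of it, so the two cannot be told apart. Compound 3 `COc1cc(-c2nn(-c3cccc(NC(=O)c4ccc(Cl)c(C(F)(F)F)c4)c3)cc2-c2ccncc2)ccc1Cl` differs from compound 2 in one place: chloro in place of hydrogen on an aromatic carbon. For the measured compounds named here, no measured pair shows this change, so its effect cannot be read from the data. The step is expected to be a modest gain, a 1.7-fold lower number from compound 2 to compound 3 (0.23 log units; within the scatter), barely beyond the scatter. Compound 3 is therefore estimated at 700 nM, in the range 250 nM to 2000 nM.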

Compound 3, half-maximal inhibitory concentration: 2420 nM
Beside the measured number, compound 3's estimate is 3.5-fold (0.54 log units) below it; measured number above the stated range.
By their numbers in this assay, from the lowest: compounds 1, 2 and 3 (each within the scatter of the next, the first and the last beyond it).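

In this assay, chloro in place of hydrogen on the aromatic carbon ortho to a trifluoromethyl group and para to a large group gives a 2.0-fold higher number from compound 2 to compound 3 (0.30 log units; within the scatter) and so leaves compound 2 and compound 3 indistinguishable. For the compounds shown here, this single pair is the first reading of the change, and it shows no difference beyond the scatter at this position. Going by these compounds alone, no evidence on these compounds bears on this step. The compounds shown leave open whether fluoro or an amine on this same carbon would read apart from hydrogen, and whether chloro there would do the same on compound 1.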